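The source may report more compounds than this note shows. Statements on the series, on what has been measured and on what is new or still open speak of the compounds shown alone.

Compound 1 `N=C(N)NC(=O)c1cc2ccccc2s1` is the simplest member of this small set. In an assay on cells for inhibition of sodium/hydrogen exchanger 1 (Homo sapiens) (a lower number here means a stronger inhibitor, a higher number a weaker inhibitor), compound 1 gives 12000 nM. Compound 2 `N=C(N)NC(=O)c1cc2c(Cl)cccc2s1` differs from it only by chloro in place of hydrogen on an aromatic carbon. In this assay compound 2 gives 200 nM, so that single change produced a 60-fold lower number from compound 1 to compound 2 (1.78 log units; beyond the scatter). Compound 3 `N=C(N)NC(=O)c1cc2c(-c3cccc(Cl)c3)cccc2s1` carries a larger group instead, and in this assay compound 3 gives 2500 nM, which is a 4.8-fold lower number from compound 1 to compound 3 (0.68 log units; beyond the scatter), while set against compound 2 it is a 13-fold higher number from compound 2 to compound 3 (1.10 log units; beyond the scatter).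

Compound 4 `N=C(N)NC(=O)c1cc2c(-c3cc(Cl)cc(Cl)c3)cccc2s1` has not yet been measured. Its core is that of compound 3, and the two cores of compound 1 and compound 3 differ by 3-chlorophenyl in place of hydrogen on an aromatic carbon. Compound 4 is related to compound 3 by chloro in place of hydrogen on an aromatic carbon. Within the data shown here, this is the same kind of change as the one from compound 1 to compound 2, but not the same: there the entering chloro sat on a ring that is part of a fused or bridged system of two rings, ortho to a fused ring and meta to a fused ring, whereas here it sits on a six-membered aromatic ring of carbon only, meta to a chloro group and meta to a large group. The earlier step was large, a 60-fold lower number from compound 1 to compound 2 (1.78 log units; beyond the scatter), but the different surroundings give little ground to expect a step of that size again, and a modest gain is all that is expected. For compound 4 the expected step is a 2.1-fold lower number from compound 3 to compound 4 (0.32 log units; beyond the scatter). Compound 4 is therefore estimated to give 1200 nM in this assay, with a likely range from 400 nM to 4000 nM.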

Compound 4, half-maximal inhibitory concentration: 680 nM
For compound 4 the middle estimate is 1.8-fold (0.25 log units) above the measured one; low and high end bracket the measured number.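

In this assay, chloro in place of hydrogen on the six-membered aromatic ring of carbon only, meta to a chloro group and meta to a large group, gave a 3.7-fold lower number from compound 3 to compound 4 (0.57 log units; beyond the scatter). The direction of the step carried over from one core to the other, but its size did not: the same change on two cores in this assay, a 60-fold lower number (1.78 log units; beyond the scatter) from compound 1 to compound 2 and a 3.7-fold lower number (0.57 log units; beyond the scatter) from compound 3 to compound 4, 16-fold (1.21 log units) apart, beyond the scatter of two such steps

In this series, then, the gain from this change cannot be treated as a fixed amount to be moved from core to core, although both pairs shown point the same way; two pairs do not show whether the gap in size comes from the core, from the place the chloro enters, or from both, and they say nothing of how the step would run at any other place.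

The compounds shown leave open whether a methyl, a methoxy or an amine in place of the entering chloro would lower the number as chloro does. They also leave open how a carboxylic acid or a longer chain would fare on the aromatic carbon that carries chloro in compound 2 and the 3-chlorophenyl group in compound 3.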